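Larger Side Group, Unknown Effect on Cell Toxicity

The compounds below may be only part of what the source reports. "The series", "measured", "known", "first", "only" and "open" are said of these compounds alone.

Compound 2 `COc1ccc(C(C)(C)NC(=O)c2ccc([N+](=O)[O-])o2)cc1` holds the highest of the two numbers recorded in an ADME assay on Vero cells (Chlorocebus sabaeus) for cytotoxicity, read by MTT assay, with a stated time of 48 h (on this read-out lower numbers stand for higher toxicity in this test and higher numbers for lower toxicity in this test), where compound 2 gives 82000 nM. Compound 1 `CC(C)(C)C(NC(=O)c1ccc([N+](=O)[O-])o1)c1ccccc1` gives 10000 nM in this assay, a lower number that lies beyond the scatter. Compound 3 `CC(C)(NC(=O)c1ccc([N+](=O)[O-])o1)c1ccc(COc2ccc(Cl)cc2)cc1` carries (4-chlorophenoxy)methyl in place of methoxy on an aromatic carbon. Going by the values given here, no measured pair shows a change of this kind, so its size is open. A moderate downward step is expected, a 2.7-fold lower number from compound 2 to compound 3 (0.44 log units; beyond the scatter), toward somewhat greater toxicity. Compound 3 is estimated at 30000 nM in this assay, with a range from 8000 nM to 100000 nM.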

Compound 3, half-maximal cytotoxic concentration: 120000 nM
For compound 3 the middle estimate is 4.0-fold (0.60 log units) below the measured one; measured number above the stated range.
By their numbers in this assay, from the lowest: compound 1; then compounds 2 and 3 (each within the scatter of the next).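

In this assay the exchange of methoxy for (4-chlorophenoxy)methyl on an aromatic carbon, para to a large group, gives a 1.5-fold higher number from compound 2 to compound 3 (0.17 log units; within the scatter) and so leaves compound 2 and compound 3 indistinguishable. This position therefore accepts a group of 9 heavy atoms with an added aromatic ring in place of one of 2 heavy atoms without a step beyond the scatter. No available evidence accounts for this result. As far as these compounds go, whether an amine or a carboxylic acid on this carbon would behave the same way remains open. So does whether the (4-chlorophenoxy)methyl group would give a similar step on the core of compound 1.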